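The compounds below may be only part of what the source reports. "The series", "measured", "known", "first", "only" and "open" are said of these compounds alone.

Of the compounds shown here, three sharing one core have been measured in an assay on membranes from HEK293 cells for displacement of a labelled ligand from Type-2 angiotensin II receptor (Homo sapiens), read by radioligand binding; a lower number here means a stronger inhibitor, a higher number a weaker inhibitor. Compound 1 `CCCCOC(=O)NS(=O)(=O)c1ccc(CCC)cc1-c1ccc(Cn2c(C3CCCCC3)nc3ccccc32)cc1` carries a cyclohexyl group on the aromatic carbon of its fused ring system and gives 130 nM in this assay. Compound 2 `CCCCOC(=O)NS(=O)(=O)c1ccc(CCC)cc1-c1ccc(Cn2c(-c3ccccc3)nc3ccccc32)cc1`, with phenyl at that carbon, gives 590 nM in this assay, and compound 3 `CCCCOC(=O)NS(=O)(=O)c1ccc(CCC)cc1-c1ccc(Cn2c(C3CC3)nc3ccccc32)cc1`, with cyclopropyl there, gives 31 nM in this assay. Compound 3 therefore stands with the lowest number of the three; the steps of a 4.2-fold lower number from compound 1 to compound 3 (0.62 log units; beyond the scatter) and a 19-fold lower number from compound 2 to compound 3 (1.28 log units; beyond the scatter) both lie beyond the scatter, and the step of a 4.5-fold higher number from compound 1 to compound 2 (0.66 log units; beyond the scatter) separates the two larger rings from one another.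

Compound 4 `CCCCOC(=O)NS(=O)(=O)c1ccc(CCC)cc1-c1ccc(Cn2c(C3CCCC3)nc3ccccc32)cc1` has not yet been measured. It differs from compound 3 in one place: cyclopentyl in place of cyclopropyl on an aromatic carbon. Among the measured compounds shown here, the steps that bear on this change are a 4.2-fold lower number from compound 1 to compound 3 (0.62 log units; beyond the scatter) and a 19-fold lower number from compound 2 to compound 3 (1.28 log units; beyond the scatter), which show that going from cyclopropyl to either of the larger saturated or aromatic rings raised the number, modestly for cyclohexyl and largely for phenyl. Cyclopentyl stands between cyclopropyl and cyclohexyl in this series, so a modest step toward a higher number in this assay is expected, short of the one seen for cyclohexyl. For compound 4 the estimated step is a 1.9-fold higher number from compound 3 to compound 4 (0.29 log units; within the scatter). Compound 4 is thus expected to give 60 nM in this assay, within a range from 25 nM to 150 nM.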

Compound 4, inhibition constant: 35 nM
For compound 4 the middle estimate is 1.7-fold (0.23 log units) above the measured one; low and high end bracket the measured number.
By their numbers in this assay, from the lowest: compounds 3 and 4 (each within the scatter of the next); then compound 1; then compound 2.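

In this assay, the saturated ring on this aromatic carbon, which lies between two ring nitrogen atoms, can go from cyclopropyl to cyclopentyl with no readable difference, at a 1.1-fold higher number from compound 3 to compound 4 (0.05 log units; within the scatter). The earlier compounds had shown only that cyclohexyl and phenyl both gave higher numbers than cyclopropyl, whereas the new steps place the first clear separation among the saturated rings between cyclopentyl and cyclohexyl, at a 3.7-fold lower number from compound 1 to compound 4 (0.57 log units; beyond the scatter), and keep phenyl well apart, at a 17-fold lower number from compound 2 to compound 4 (1.23 log units; beyond the scatter); among these rings the number therefore does not rise evenly with ring size, and compound 2 stands apart from all three saturated examples. No measurement shown here accounts for this behaviour at this position.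

The compounds shown leave open whether an open chain such as isopropyl or butyl on this carbon, or a cyclobutyl ring, would fall with compound 3 and compound 4 or nearer compound 1. They also leave open whether a saturated ring carrying an amine, or an aromatic ring such as pyridyl or thienyl, would behave like cyclopentyl or like phenyl.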